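The compounds below may be only part of what the source reports. "The series", "measured", "known", "first", "only" and "open" are said of these compounds alone.

In a functional assay on NSCLC cells (Homo sapiens) for antiproliferative activity (a higher number here means a weaker inhibitor of growth, a lower number a stronger inhibitor of growth), compound 3 `N=C(N)N/N=C/c1c(-c2cccnc2)nc2sc(Cl)cn12` gives 41700 nM, a number within the scatter of compound 1 `Cc1cn2c(/C=N/NC(=N)N)c(-c3ccncc3)nc2s1` at 33100 nM, while compound 2 `N=C(N)N/N=C/c1c(-c2ccccn2)nc2sc(Cl)cn12` gives 18600 nM. Compound 4 `N=C(N)N/N=C/c1c(-c2ccncc2)nc2sc(Cl)cn12` follows from compound 3 by one change: pyridin-4-yl in place of pyridin-3-yl on an aromatic carbon. For the measured compounds named here, the only measured step at this place is a 2.2-fold higher number from compound 2 to compound 3 (0.35 log units; beyond the scatter), and it is modest. Compound 1 also bears pyridin-4-yl and gives 33100 nM. No step beyond the scatter is therefore expected in this assay, and the direction remains uncertain. The expected change is a 1.4-fold lower number from compound 3 to compound 4 (0.14 log units; within the scatter). The estimated value for compound 4 is 30000 nM, with an expected range from 15000 nM to 60000 nM.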

Compound 4, concentration for total growth inhibition: 17000 nM
The estimate for compound 4 lay 1.8-fold (0.25 log units) above the measured number; measured number inside the range.
By their numbers in this assay, from the lowest: compounds 4, 2, 1 and 3 (each within the scatter of the next, the first and the last beyond it).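

In this assay pyridin-4-yl in place of pyridin-3-yl gives a 2.5-fold lower number from compound 3 to compound 4 (0.39 log units; beyond the scatter) and so, with the earlier step, sets pyridin-3-yl apart from both other pyridinyl groups at this aromatic carbon, while pyridin-4-yl in place of pyridin-2-yl gives a 1.1-fold lower number from compound 2 to compound 4 (0.04 log units; within the scatter). Chloro in place of methyl, with pyridin-4-yl held constant, gives a 1.9-fold lower number from compound 1 to compound 4 (0.29 log units; within the scatter) and thus no step beyond the scatter. No measured evidence explains the pyridin-3-yl result. The compounds leave open whether a phenyl ring or a pyrimidine would fit this pattern at the same carbon, and how an amine would behave in place of the chloro.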